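This account rests on a few compounds, and the source may have more. Where it says the series, first, only, none or still open, it means among the compounds named here.

Compound 2 `CC(C)=CCC1Cc2c(OCCCNC(=O)c3cccs3)cc(=O)n(CCCO)c2CC1(C)C` gives 5.6% in a functional assay on PANC-1 cells (Homo sapiens) for inhibition, read by MTT assay, with a stated time of 24 h, tested at 10 uM (on this read-out higher numbers stand for more inhibition at the one concentration tested (going by the name of the read-out) and lower numbers for less inhibition), and compound 1 `CC(C)=CCC1Cc2c(OCCCNS(=O)(=O)c3ccc(Br)cc3)cc(=O)n(CCCO)c2CC1(C)C` gives 3.7% in the same assay; the two numbers sit within the usual scatter of each other, as the step of a number 1.9 percentage points higher from compound 1 to compound 2 (within the scatter) shows. Compound 3 `COc1ccc(OCCCOc2cc(=O)n(CCCO)c3c2CC(CC=C(C)C)C(C)(C)C3)cc1` is the next compound, differing from compound 2 by 4-methoxyphenoxy in place of ((thiophen-2-yl)carbonyl)amino on a saturated chain carbon, three bonds along the chain from an oxygen on an aromatic ring. Within the data shown here, the one step measured so far touched the same end of the chain and stayed within the scatter, and both measured compounds showed little inhibition, so compound 3 is expected to stay at a similar low level, with a step of a number 0.6 percentage points lower from compound 2 to compound 3 (within the scatter). The estimate for compound 3 is 5%, between -3% and 14%.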

Compound 3, a percentage reported as inhibition, at one concentration (the size of the read-out at that concentration, not a potency): 4.1%
The estimate for compound 3 lay 0.9 percentage points above the measured number; the range from low to high includes it.
By their numbers in this assay, from the lowest: compounds 1, 3 and 2 (each within the scatter of the next).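

At the end of the chain, 4-methoxyphenoxy in place of ((thiophen-2-yl)carbonyl)amino gives a number 1.5 percentage points lower from compound 2 to compound 3 (within the scatter) in this assay, while the same group in place of ((4-bromophenyl)sulfonyl)amino gives a number 0.4 percentage points higher from compound 1 to compound 3 (within the scatter) in the same assay. This position therefore now includes a group with no nitrogen and no hydrogen-bond donor, and the number stays within the scatter of both earlier compounds. Nothing available explains why these numbers stay so close. Still open, on these data alone, is whether an amine or a carboxylic acid at this chain end, or a longer chain, would lift inhibition beyond the scatter.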